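The source may report more compounds than this note shows. Statements on the series, on what has been measured and on what is new or still open speak of the compounds shown alone.

Of the compounds shown here, three built on one shared core have been measured in an ADME assay on HaCaT cells (Homo sapiens) for cytotoxicity, read by MTT assay, with a stated time of 72 h; on this read-out higher numbers stand for weaker inhibition and lower numbers for stronger inhibition. Compound 1 `Cc1cc(-c2ccccc2)n(/C(N)=N/S(=O)(=O)c2cc(C)c(Cl)cc2SCc2cccc3ccccc23)n1` gives 12000 nM. Compound 2 `Cc1ccc(CSc2cc(Cl)c(C)cc2S(=O)(=O)/N=C(\N)n2nc(C)cc2-c2ccccc2)cc1` gives 30000 nM. Compound 3 `Cc1cc(-c2ccccc2)n(/C(N)=N/S(=O)(=O)c2cc(C)c(Cl)cc2SCc2ccc(C(F)(F)F)cc2)n1` gives 18000 nM, the second highest of the three numbers; its gap to compound 1 and its gap to compound 2 each lie within the scatter. Compound 4 `Cc1cc(-c2ccccc2)n(/C(N)=N/S(=O)(=O)c2cc(C)c(Cl)cc2SCc2cccc(Cl)c2)n1` has not yet been measured in this assay. The change from compound 3 is 3-chlorophenyl in place of 4-(trifluoromethyl)phenyl on a saturated chain carbon bound to a sulfur. Two measured steps alter the same saturated chain carbon bound to a sulfur: a 2.5-fold higher number from compound 1 to compound 2 (0.40 log units; beyond the scatter), while a 1.5-fold higher number from compound 1 to compound 3 (0.18 log units; within the scatter). A third step keeps that ring and alters only a substituent on it: a 1.7-fold lower number from compound 2 to compound 3 (0.22 log units; within the scatter). Among the compounds with values here, no measured step exchanges a 4-(trifluoromethyl)phenyl for a 3-chlorophenyl, and the two aryl-for-aryl steps seen so far are modest or within the scatter, so no step beyond the scatter is looked for. For compound 4 the expected step is no change at the digits printed from compound 3 to compound 4 (within the scatter). Compound 4 is therefore estimated to give 18000 nM, with a range from 9000 nM to 36000 nM.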

Compound 4, half-maximal inhibitory concentration: 18000 nM
Compound 4: middle estimate and measured number agree at the digits printed; the range from low to high includes it.
By their numbers in this assay, from the lowest: compounds 1, 3, 4 and 2 (each within the scatter of the next, the first and the last beyond it).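

In this assay, moving from 4-(trifluoromethyl)phenyl to 3-chlorophenyl on the saturated chain carbon bound to a sulfur gives no change at the digits printed from compound 3 to compound 4 (within the scatter), so this exchange of both substituent and ring placement leaves the read-out unresolved from compound 3. The other two new steps, a 1.7-fold lower number from compound 2 to compound 4 (0.22 log units; within the scatter) and a 1.5-fold higher number from compound 1 to compound 4 (0.18 log units; within the scatter), also lie within the scatter, leaving a 2.5-fold higher number from compound 1 to compound 2 (0.40 log units; beyond the scatter) as the only step among these four compounds that lies beyond it. The data offer no measurement that would explain this result.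

With substituent and placement changed together, the compounds shown cannot separate the part played by each, as a 4-chlorophenyl could begin to do. They also leave open how the read-out responds when an amine or a carboxylic acid is carried on that ring, or when a longer chain joins the ring to the sulfur.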